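A few compounds are considered here, and "the series" means these few. Any claim that something is new, unique, unknown or untested is made for them only; others in the source may bear on it.

For the measured compounds named here, compound 2 `CCCn1cnc2c(NCCCc3ccccc3)ncnc21` gives 18600 nM in an assay on CHO cells for displacement of a labelled ligand from adenosine receptor A1 (Homo sapiens) (on this read-out lower numbers stand for stronger inhibition and higher numbers for weaker inhibition), the highest of the two numbers measured so far, while compound 1 `CCCn1c(-c2ccco2)nc2c(N)nc(NCCCc3ccccc3)nc21` shows 230 nM. Compound 3 `CCCn1c(Br)nc2c(NCCCc3ccccc3)ncnc21` differs from compound 2 by bromo in place of hydrogen on an aromatic carbon. Going by the values given here, no measured pair isolates this single change, and compound 1 differs from compound 2 in more than one place, so its number cannot be read as a guide to this step alone. A modest gain in this assay is nonetheless expected, a step of a 3.7-fold lower number from compound 2 to compound 3 (0.57 log units; beyond the scatter). Compound 3 is expected to give 5000 nM, within a range from 1500 nM to 15000 nM.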

Compound 3, inhibition constant: 2670 nM
Estimate against measurement, compound 3: 1.9-fold (0.27 log units) above, and the stated range covers the measured number.
By their numbers in this assay, from the lowest: compound 1; then compound 3; then compound 2.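

For the compounds shown here, this is the first pair that isolates one change: bromo in place of hydrogen on an aromatic carbon, between two ring nitrogen atoms, gives a 7.0-fold lower number from compound 2 to compound 3 (0.84 log units; beyond the scatter) in this assay and shows that this carbon can carry a bromine atom with a gain beyond the scatter. Nothing available explains why the number falls. Still open, as far as these compounds go, is whether the gain is special to bromo, since chloro, a methyl group or an amine on the same carbon stand outside this pair. A single pair also cannot show whether bromo would give a similar step on a different core.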